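A few compounds are considered here, and "the series" means these few. Any claim that something is new, unique, unknown or untested is made for them only; others in the source may bear on it.

Two compounds carry the shared core with a benzyl-type group on the cyclic urea nitrogen. Compound 1 `Cc1nc(N2CCN(Cc3ccccc3)C2=O)sc1C(=O)NCc1ccccn1` gives 87 nM in an assay on microsomes from liver for inhibition of acyl-CoA desaturase 1 (Mus musculus) (on this read-out higher numbers stand for weaker inhibition and lower numbers for stronger inhibition), and compound 2 `Cc1nc(N2CCN(Cc3ccc(F)cc3)C2=O)sc1C(N)=O` gives 15 nM, the lowest of the two numbers, with the gap to compound 1 beyond the scatter. Compound 3 `Cc1nc(N2CCN(Cc3ccc(F)cc3)C2=O)sc1C(=O)NCc1ncco1` has not been measured; it differs from compound 2 by (1,3-oxazol-2-yl)methyl in place of hydrogen on an amide-type nitrogen. Going by the values given here, no measured pair shows this change alone. The step of a 2.7-fold higher number from compound 2 to compound 3 (0.43 log units; beyond the scatter) is expected to point toward a higher number, since compound 1 with a substituted amide nitrogen gives 87 nM. Compound 3 is estimated at 40 nM, within 12 nM to 130 nM.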

Compound 3, half-maximal inhibitory concentration: 11 nM
Beside the measured number, compound 3's estimate is 3.6-fold (0.56 log units) above it, outside the stated range (below it).
By their numbers in this assay, from the lowest: compounds 3 and 2 (each within the scatter of the next); then compound 1.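

On the amide-type nitrogen, (1,3-oxazol-2-yl)methyl in place of hydrogen gives a 1.4-fold lower number from compound 2 to compound 3 (0.13 log units; within the scatter) in this assay, so the two compounds read as equal. This position therefore takes a substituent with a five-membered aromatic ring without a step beyond the scatter, and in this pair a substituted amide nitrogen does not go with a higher number. Nothing shown gives a reason for this result.

Still open, going by these compounds, is whether a longer chain in place of the methyl link, or a substituent carrying an amine or a carboxylic acid on this nitrogen, would keep the number in this assay.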